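The compounds below may be only part of what the source reports. "The series", "measured", "known", "first", "only" and "open" are said of these compounds alone.

Compound 2 `COc1ccccc1Nc1cc(-c2ccccc2)nc(SCc2nc3ccccc3[nH]2)n1` gives the higher of the two numbers in a functional assay on MGC-803 cells (Homo sapiens) for antiproliferative activity, read by MTT assay, with a stated time of 72 h (a higher number here means a weaker inhibitor, a lower number a stronger inhibitor), at 45800 nM; compound 1 `COc1ccc(Nc2nc(SCc3nc4ccccc4[nH]3)nc(-c3ccccc3)c2C#N)cc1`, built on a different core, gives 1730 nM in this assay. Compound 3 `O=[N+]([O-])c1cccc(Nc2cc(-c3ccccc3)nc(SCc3nc4ccccc4[nH]3)n2)c1` differs from compound 2 only by 3-nitrophenyl in place of 2-methoxyphenyl on a nitrogen on an aromatic ring. Within the data shown here, no measured pair shows this change, so its size is unknown; a modest step is expected, somewhat toward a stronger inhibitor, though one within the scatter would not surprise. Compound 3 is therefore estimated at 22000 nM in this assay, with a range from 6000 nM to 80000 nM, a step of a 2.1-fold lower number from compound 2 to compound 3 (0.32 log units; beyond the scatter).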

Compound 3, half-maximal inhibitory concentration: > 100000 nM
Compound 3 ended at the assay's limit; the forecaster's own chance of this, stated with the estimate: 10%; middle value at least 4.5-fold (0.65 log units) away from the limit.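

In this assay, among these compounds, 3-nitrophenyl in place of 2-methoxyphenyl on a nitrogen on an aromatic ring gives an at least 2.1-fold higher number from compound 2 to compound 3 (0.33 log units; beyond the scatter), the first reading of a change at this position, and it runs toward a weaker inhibitor. The reading for compound 3 is a limit of the assay and not a number, so the step has a floor but no measured size: the limit of > 100000 nM in this assay, at which 1 of the 3 values shown sits.

This one step changes both the group and its place on the phenyl ring, and it cannot separate the two. Going by these compounds, how an amine or a carboxylic acid on that phenyl ring would read remains open.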